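Chloro in place of hydroxy on the aryl ketone

The source may hold more compounds than are shown below. What is called first, only, known or untested is meant among the compounds shown, and "the series" means these compounds.

Compound 1 `COc1ccc(C(=O)/C=C/c2cc3ccccc3[nH]c2=O)cc1`: 31600 nM
Compound 2 `O=C(/C=C/c1cc2ccccc2[nH]c1=O)c1ccc(O)cc1`: 9910 nM

Both compounds share one core and differ only on the oxygen of the outer aromatic ring. Among the measured compounds shown here, in an ADME assay on HCT-116 cells (Homo sapiens) for cytotoxicity, read by sulforhodamine B assay, with a stated time of 24 h (on this read-out higher numbers stand for lower toxicity in this test and lower numbers for higher toxicity in this test), compound 1 gives 31600 nM, while compound 2 gives 9910 nM, the lowest of the two numbers recorded; the one step recorded, a 3.2-fold lower number from compound 1 to compound 2 (0.50 log units; beyond the scatter), sets compound 2 apart from compound 1.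

Compound 3 `O=C(/C=C/c1cc2ccccc2[nH]c1=O)c1ccc(Cl)cc1` carries chloro in place of hydroxy on an aromatic carbon. For the measured compounds named here, no measured step shows a chloro entering at this place, so the step from compound 1 to compound 2 bears on it only loosely: it shows that a single small change on this ring can move the number beyond the scatter, without telling which way a chloro would push. The expectation for compound 3 is therefore a modest move at most, a 1.2-fold higher number from compound 2 to compound 3 (0.08 log units; within the scatter), and compound 3 is estimated at 12000 nM with a range from 3000 nM to 40000 nM.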

Compound 3, concentration lethal to 50% of the cells: 66500 nM
Beside the measured number, compound 3's estimate is 5.5-fold (0.74 log units) below it; measured number above the stated range.
By their numbers in this assay, from the lowest: compound 2; then compound 1; then compound 3.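

Until now, this place on the ring had shown only a fall in the number, on going from methoxy to hydroxy, but in this assay chloro shows that it can also rise, with a 6.7-fold higher number from compound 2 to compound 3 (0.83 log units; beyond the scatter) as the largest step among the three compounds. Chloro also stands apart from methoxy, with a 2.1-fold higher number from compound 1 to compound 3 (0.32 log units; beyond the scatter) as a smaller but still real step, so hydroxy gives the highest toxicity in this test and chloro the lowest. Nothing here explains why these groups rank in this order.

Three groups at one place cannot show whether other groups would continue this order. An amine, a carboxylic acid or a fluoro group at this carbon could test it, and chloro at another carbon of the ring remains an open question.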